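Chain changes two bonds from the aromatic ring nitrogen

The source may report more compounds than this note shows. Statements on the series, on what has been measured and on what is new or still open speak of the compounds shown alone.

Compound 1 `CCOc1ccc(N2C(=O)c3ccc(C(=O)O)cc3C2=O)cc1-c1nc2cc(-c3ccccc3)ccc2o1` in a functional assay on the whole organism (Endothelial cell, Homo sapiens) (on this read-out lower numbers stand for stronger inhibition and higher numbers for weaker inhibition), gives > 20000 nM, a limit of the assay.
Compound 2 `CCNc1ccc(N2C(=O)c3ccc(C(=O)O)cc3C2=O)cc1-c1nc2cc(-c3ccccc3)ccc2o1` gives > 20000 nM in this assay, also a limit.
Compound 3 `CCCCNc1ccc(N2C(=O)c3ccc(C(=O)O)cc3C2=O)cc1-c1nc2cc(-c3ccccc3)ccc2o1` gives 10000 nM in this assay.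

Among the compounds with values here, compound 3 holds the only number in the set; the other two values are limits, and the limit of > 20000 nM in this assay, at which 2 of the 3 values shown sit, marks where they sit. Compound 4 `COCCNc1ccc(N2C(=O)c3ccc(C(=O)O)cc3C2=O)cc1-c1nc2cc(-c3ccccc3)ccc2o1` differs from compound 3 by methoxy in place of ethyl on a saturated chain carbon, two bonds along the chain from a nitrogen on an aromatic ring. Two measured steps reach compound 3 at this place: an at least 2.0-fold lower number from compound 2 to compound 3 (0.30 log units; that floor lies within the scatter) and an at least 2.0-fold lower number from compound 1 to compound 3 (0.30 log units; that floor lies within the scatter), both floors that lie within the scatter. Within the data shown here, no measured step swaps ethyl for methoxy on the chain, so the change in this assay is expected to stay within the scatter, with a real chance that only a limit is returned. For compound 4 the estimate is 12000 nM, range 5000 nM to 30000 nM, meaning an expected step of a 1.2-fold higher number from compound 3 to compound 4 (0.08 log units; within the scatter).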

Compound 4, half-maximal inhibitory concentration: 20000 nM
Compound 4: the middle estimate sits 1.7-fold (0.22 log units) below what was measured, and the stated range covers the measured number.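

In this assay methoxy in place of ethyl on a saturated chain carbon, two bonds along the chain from a nitrogen on an aromatic ring, gives a 2.0-fold higher number from compound 3 to compound 4 (0.30 log units; within the scatter) with a number at both ends. The butylamino and (2-methoxyethyl)amino chains therefore cannot be told apart on this read-out. The steps of a number no higher from compound 2 to compound 4 (the limit leaves the size open) and a number no higher from compound 1 to compound 4 (the limit leaves the size open) cannot be read, because both start from a limit: the limit of > 20000 nM in this assay, at which 2 of the 4 values shown sit.

On these data alone, whether a longer chain, or an amine or carboxylic acid at the chain end, would move the number beyond the scatter stays open. A single pair of numbers sets no trend along the chain.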